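Cyclopentyl in place of hydrogen at the ketone side chain

The compounds below may be only part of what the source reports. "The series", "measured", "known", "first", "only" and "open" are said of these compounds alone.

The series shares one core, seen in compound 1 `Cc1c(OCCCCOc2ccc(C(=O)O)cc2Cl)ccc(C(=O)CC2CCCC2)c1O`, compound 2 `Cc1cc(OCCCCOc2ccc(C(=O)CC3CCCC3)c(O)c2C)ccc1C(=O)O` and compound 3 `CC(=O)c1ccc(OCCCCOc2ccc(C(=O)O)cc2C)c(C)c1O`. In an assay on HEK293 cells for positive allosteric modulation of metabotropic glutamate receptor 2 (Rattus norvegicus), read by thallium flux, with a stated time of 2.5 min (a higher number here means a larger maximal response, a lower number a smaller maximal response), compound 1 gives 82.2%, compound 2 gives 83.6% and compound 3 gives 83.1%; compound 3 thus sits among three numbers that all lie within the scatter of one another, closest to compound 2 and slightly apart from compound 1. For the measured compounds named here, the one measured step, a number 1.4 percentage points higher from compound 1 to compound 2 (within the scatter), changes the aryl group on the ether oxygen and does not bear directly on the change to compound 4 `Cc1cc(C(=O)O)ccc1OCCCCOc1ccc(C(=O)CC2CCCC2)c(O)c1C`. That change is cyclopentyl in place of hydrogen on a saturated chain carbon bound to a carbonyl carbon. Compound 1 and compound 2 already carry the cyclopentyl group at this place, and their values match that of compound 3, which lacks it, so no step beyond the scatter is expected from compound 3 to compound 4: a number 0.1 percentage points lower from compound 3 to compound 4 (within the scatter). Compound 4 is therefore estimated at 83%, within 73% to 93%.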

Compound 4, largest response reached (reported as percent of maximum), in percent of the reference or control that the assay uses: 84.6%
For compound 4 the middle estimate is 1.6 percentage points below the measured one; low and high end bracket the measured number.
By their numbers in this assay, from the lowest: compounds 1, 3, 2 and 4 (each within the scatter of the next).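

In this assay, for the compounds shown here, the direct step for this change, a number 1.5 percentage points higher from compound 3 to compound 4 (within the scatter), shows that cyclopentyl in place of hydrogen on a saturated chain carbon bound to a carbonyl carbon leaves the maximal response unchanged within the scatter, which the earlier compounds suggested only across more than one difference. The other two steps agree at neighbouring changes, since 4-carboxy-2-methylphenyl in place of 4-carboxy-3-methylphenyl gives a number 1 percentage points higher from compound 2 to compound 4 (within the scatter) and methyl in place of chloro on an aromatic carbon gives a number 2.4 percentage points higher from compound 1 to compound 4 (within the scatter) as well. Nothing available here offers an explanation for these steps.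

The compounds shown leave open whether a cyclohexyl group or an amine at this place would hold the response in the same range. They also leave open whether an amide could stand in place of the carboxylic acid.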